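Replacing the mesylate of compound 2 with an amine

The compounds below may be only part of what the source reports. "The series", "measured", "known", "first", "only" and "open" are said of these compounds alone.

The two measured compounds:
- In an assay on cell membranes for displacement of a labelled ligand from proteinase-activated receptor 1 (Homo sapiens), read by scintillation counting, with a stated time of 60 min (a lower number here means a stronger inhibitor, a higher number a weaker inhibitor), compound 1 `Fc1cccc(-c2ccc(/C=C/[C@H]3C(OCc4ccccc4)C[C@@H]4CCCC[C@@H]43)nc2)c1` gives 280 nM.
- In this assay compound 2 `CS(=O)(=O)OC1C[C@@H]2CCCC[C@@H]2[C@H]1/C=C/c1ccc(-c2cccc(F)c2)cn1` gives 6.4 nM.

Within the data shown here, compound 2 holds the lowest number of the two, and the only step available is the one that leads to it: a 44-fold lower number from compound 1 to compound 2 (1.64 log units; beyond the scatter). That single step shows how strongly the group on the oxygen of the shared core can move the result.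

Compound 3 `NC1C[C@@H]2CCCC[C@@H]2[C@H]1/C=C/c1ccc(-c2cccc(F)c2)cn1` is the untested compound. It differs from compound 2 in one place: amino in place of (methylsulfonyl)oxy on a saturated ring carbon. Among the measured compounds shown here, no measured step involves an amine, so the step from compound 1 to compound 2 bears only loosely on it; it says that this position is sensitive, not which way a small donor group would push. With the (methylsulfonyl)oxy group that accompanied the strong number of compound 2 removed, a weaker result seems more likely than a stronger one. Compound 3 is therefore expected to give about 100 nM in this assay, within a wide range from 15 nM to 700 nM, an estimated step of a 16-fold higher number from compound 2 to compound 3 (1.19 log units; beyond the scatter).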

Compound 3, half-maximal inhibitory concentration: 230 nM
The estimate for compound 3 lay 2.3-fold (0.36 log units) below the measured number; the measured number falls inside the stated range.
By their numbers in this assay, from the lowest: compound 2; then compounds 3 and 1 (each within the scatter of the next).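

In this assay, putting amino in place of (methylsulfonyl)oxy gives a 36-fold higher number from compound 2 to compound 3 (1.56 log units; beyond the scatter), so the low number of compound 2 does not carry over to this replacement. The earlier step showed that benzyloxy and (methylsulfonyl)oxy differ widely on this saturated ring carbon, but it could not show whether (methylsulfonyl)oxy was unusually favourable or benzyloxy unusually poor. The new comparison helps to separate those readings: benzyloxy and amino, two unlike groups, cannot be told apart, with a 1.2-fold lower number from compound 1 to compound 3 (0.09 log units; within the scatter), so among these three compounds (methylsulfonyl)oxy alone stands apart. Nothing available here explains why this group gives the lower number.

The compounds shown leave open whether the low number depends on the sulfonyl part, on the oxygen that joins it to the ring, or on both, and a methylsulfonylamino group on the same carbon would help to separate these possibilities. They also leave open how a hydroxyl group, an acetyloxy group or a longer sulfonate such as ethylsulfonyloxy would compare with the three groups seen so far.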